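The source may report more compounds than this note shows. Statements on the series, on what has been measured and on what is new or still open speak of the compounds shown alone.

In a functional assay on DU-145 cells (Homo sapiens) for cytotoxicity, read by CCK-8 assay and cell counting, with a stated time of 2 days (a lower number here means a stronger inhibitor, a higher number a weaker inhibitor), compound 1 `Oc1ccc(-c2cc(-c3ccc(Cl)cc3)nc(-c3cccnc3)c2)cc1` gives 22800 nM. Compound 2 `Oc1cccc(-c2cc(-c3ccncc3)nc(-c3cccc(Cl)c3)c2)c1` gives "not determined" (no result reported) in this assay.

Compound 1 stands alone with the only number shown; compound 2 carries no value in this assay. Compound 3 `Oc1ccc(-c2cc(-c3ccc(Cl)cc3)nc(-c3cccs3)c2)cc1` differs from compound 1 by thiophen-2-yl in place of pyridin-3-yl on an aromatic carbon. Among the compounds with values here, with no comparable step among measured compounds, the direction is open; a modest step in this assay is expected, and the estimate for compound 3 is 15000 nM (5000 nM to 50000 nM), a step of a 1.5-fold lower number from compound 1 to compound 3 (0.18 log units; within the scatter) that may not exceed the scatter.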

Compound 3, half-maximal inhibitory concentration: 7660 nM
Compound 3: the middle estimate sits 2.0-fold (0.29 log units) above what was measured, and the stated range covers the measured number.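

In this assay, thiophen-2-yl in place of pyridin-3-yl on the aromatic carbon next to the ring nitrogen gives a 3.0-fold lower number from compound 1 to compound 3 (0.47 log units; beyond the scatter). This first readable step shows that the number at this position responds to exchanging one aromatic ring for another, here a six-membered ring with nitrogen for a five-membered ring with sulfur. No measurement shown gives a reason for this step. The compounds shown leave open how a phenyl ring, a furan-2-yl group or an amine would read at this position.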